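Bromo to methyl: compound 3 to compound 4

The source may hold more compounds than are shown below. What is called first, only, known or untested is meant among the compounds shown, and "the series" means these compounds.

In a functional assay on HeLa cells (Homo sapiens) for antiproliferative activity, read by MTT assay, with a stated time of 48 h (on this read-out lower numbers stand for stronger inhibition and higher numbers for weaker inhibition), compound 1 (`Cc1ccc2[nH]c(-c3cn(-c4ccccc4)nc3-c3ccccc3)nc2c1`) gives 6560 nM, compound 2 (`Clc1ccc(-c2nn(-c3ccccc3)cc2-c2nc3ccccc3[nH]2)cc1`) gives 1650 nM and compound 3 (`Clc1ccc(-c2nn(-c3ccccc3)cc2-c2nc3cc(Br)ccc3[nH]2)cc1`) gives 2160 nM. Compound 3 thus holds the second highest of the three numbers, within the scatter of compound 2 and well under compound 1.

The next structure is compound 4 (`Cc1ccc2[nH]c(-c3cn(-c4ccccc4)nc3-c3ccc(Cl)cc3)nc2c1`), with methyl in place of bromo on an aromatic carbon.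

Going by the values given here, one measured step bears directly on this place, a 1.3-fold higher number from compound 2 to compound 3 (0.12 log units; within the scatter). Bromo in place of hydrogen therefore left the number within the scatter, and the data hold no measured step from bromo to methyl. Among the compounds with values here, compound 4 carries a chloro group that compound 1 lacks, though both carry the methyl group, so compound 1 at 6560 nM gives no clean step for this change. It does leave some room for a weaker result, so any shift is expected to lean slightly upward, and no change beyond the scatter is expected in this assay.

The expected change is small, an estimated 1.2-fold higher number from compound 3 to compound 4 (0.08 log units; within the scatter). For compound 4 the estimated value is 2600 nM, with an expected range of 1200 nM to 5500 nM.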

Compound 4, half-maximal inhibitory concentration: 5360 nM
Compound 4: the middle estimate sits 2.1-fold (0.31 log units) below what was measured; measured number inside the range.
By their numbers in this assay, from the lowest: compounds 2 and 3 (each within the scatter of the next); then compounds 4 and 1 (each within the scatter of the next).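

At this position, on the six-membered aromatic ring of carbon only that is part of the fused system, the earlier step of a 1.3-fold higher number from compound 2 to compound 3 (0.12 log units; within the scatter) gave no sign that the group there matters, but methyl separates from both bromo and hydrogen, with a 2.5-fold higher number from compound 3 to compound 4 (0.39 log units; beyond the scatter) and a 3.2-fold higher number from compound 2 to compound 4 (0.51 log units; beyond the scatter) in this assay as the two readings beyond the scatter. The position is therefore not indifferent to its substituent in these compounds, and with the methyl group in place the chloro group on the other aromatic ring leaves the number within the scatter, as a 1.2-fold lower number from compound 1 to compound 4 (0.09 log units; within the scatter) records. Nothing at hand gives a measured reason for the gap between methyl and the other two groups.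

Three groups at one position, all carried with the chloro group except in compound 1, cannot show whether the methyl result reflects a trend or a single case. From the compounds shown here alone, a methoxy group, an amine or a carboxylic acid at this position would test that, and whether bromo and hydrogen also stay within the scatter of each other without the chloro group remains open.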